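The source may hold more compounds than are shown below. What is called first, only, known or untested is meant among the compounds shown, and "the series" means these compounds.

Compound 1 `Nc1cc(C2CCC2)nc2ccc(NC(=O)/C=C/c3ccc(C(F)(F)F)cc3)cc12`: 250 nM
Compound 2 `Nc1cc(C2CCCCC2)nc2ccc(NC(=O)/C=C/c3ccc(C(F)(F)F)cc3)cc12`: 96 nM
Compound 3 `Cc1cc(N)c2cc(NC(=O)/C=C/c3ccc(C(F)(F)F)cc3)ccc2n1`: 140 nM

All three were tested in a functional assay on HEK293 cells for activation of melanin-concentrating hormone receptor 1 (Homo sapiens), read by inositol phosphate accumulation; a lower number here means that less compound is needed, a higher number that more compound is needed for the effect. On these numbers compound 3 sits between the other two, and both neighbours are within the scatter of it: a 1.8-fold lower number from compound 1 to compound 3 (0.25 log units; within the scatter) and a 1.5-fold higher number from compound 2 to compound 3 (0.16 log units; within the scatter). Compound 4 `CCC(C)c1cc(N)c2cc(NC(=O)/C=C/c3ccc(C(F)(F)F)cc3)ccc2n1` is not yet measured; it differs from compound 3 in one place: sec-butyl in place of methyl on an aromatic carbon. All three measured steps swap the group at this same position, and only one of them is beyond the scatter: a 2.6-fold lower number from compound 1 to compound 2 (0.42 log units; beyond the scatter). Changes here have so far moved the number modestly at most, so for compound 4 a small drop or no step beyond the scatter is expected, a 1.3-fold lower number from compound 3 to compound 4 (0.10 log units; within the scatter). Compound 4 is thus estimated at 110 nM, with a range from 50 nM to 250 nM.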

Compound 4, half-maximal effective concentration: 44 nM
Compound 4: middle estimate off by 2.5-fold (0.40 log units), on the high side, outside the stated range (below it).
By their numbers in this assay, from the lowest: compound 4; then compounds 2, 3 and 1 (each within the scatter of the next, the first and the last beyond it).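

Among the compounds shown here, at this position, sec-butyl is the first group to move the number beyond the scatter from methyl, with a 3.2-fold lower number from compound 3 to compound 4 (0.50 log units; beyond the scatter). The open chain also gives a lower number than either ring group, with a 2.2-fold lower number from compound 2 to compound 4 (0.34 log units; beyond the scatter) and a 5.7-fold lower number from compound 1 to compound 4 (0.75 log units; beyond the scatter), so the two ring groups do not set the limit here. No measurement at hand explains why this chain does better.

From the compounds shown here alone, whether the branch matters stays open: a straight butyl chain would test that. An isopropyl group, or a chain ending in an amine, would show how much change this position tolerates.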